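Sulfonylacetic acid head on the methylsulfonylpropoxy biaryl

A few compounds are considered here, and "the series" means these few. Any claim that something is new, unique, unknown or untested is made for them only; others in the source may bear on it.

Measured so far in a functional assay on CHO cells for agonist activity at Free fatty acid receptor 1 (Homo sapiens), read by FLIPR and calcium flux; a lower number here means that less compound is needed, a higher number that more compound is needed for the effect:
- compound 1, `Cc1cc(OCCCS(C)(=O)=O)cc(C)c1-c1cccc(COc2ccc(CCC(=O)O)cc2)c1`: 15.5 nM
- compound 2, `Cc1cc(OCC2CC2)cc(C)c1-c1cccc(COc2ccc(S(=O)(=O)CC(=O)O)cc2)c1`: 79.4 nM

Compound 1 gives the lower of the two numbers in this assay; compound 2 sits at a higher number, and that gap lies beyond the scatter. Going by the values given here, compound 1 and compound 2 differ in more than one place, so no single step between them is defined; their two values show only that the whole set of changes in compound 2 costs potency.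

Compound 3, `Cc1cc(OCCCS(C)(=O)=O)cc(C)c1-c1cccc(COc2ccc(S(=O)(=O)CC(=O)O)cc2)c1`, is the pairing of the side chain of compound 1 with the acid head of compound 2: (carboxymethyl)sulfonyl in place of 2-carboxyethyl on an aromatic carbon. Among the compounds with values here, no step between two measured compounds isolates this head change. A moderate rise in the number is expected from compound 1 to compound 3, a 2.6-fold higher number from compound 1 to compound 3 (0.41 log units; beyond the scatter), on the reading that the gap to compound 2 at 79.4 nM is shared between its two changes rather than carried by the head alone. For compound 3 in this assay the expected value is 40 nM, with a range of 15 nM to 110 nM.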

Compound 3, half-maximal effective concentration: 170 nM
Beside the measured number, compound 3's estimate is 4.3-fold (0.63 log units) below it, outside the stated range (above it).
By their numbers in this assay, from the lowest: compound 1; then compound 2; then compound 3.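

In this assay, the head change on an aromatic carbon, para to a large group, now has a step of its own: (carboxymethyl)sulfonyl in place of 2-carboxyethyl gives an 11-fold higher number from compound 1 to compound 3 (1.04 log units; beyond the scatter) and counts as large. The side chain also has a step of its own on the (carboxymethyl)sulfonyl head: 2-(methylsulfonyl)ethyl in place of cyclopropyl gives a 2.1-fold higher number from compound 2 to compound 3 (0.33 log units; beyond the scatter) and counts as modest, so the cyclopropyl compound holds the lower number on this head, and the head step is the larger of the two single changes. No measurement at hand speaks to the origin of either step.

How the cyclopropyl side chain behaves on the 2-carboxyethyl head stays open, as the compounds shown pair cyclopropyl only with the (carboxymethyl)sulfonyl head, so the side-chain step is known on one head alone. Also open, from the compounds shown here alone, is whether the sulfonyl link itself carries the head step, a question that a carboxymethoxy head, with an ether oxygen in place of the sulfonyl, would help to separate.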